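A few compounds are considered here, and "the series" means these few. Any claim that something is new, unique, unknown or untested is made for them only; others in the source may bear on it.

Working notes on the series around compound 1 `CC(=O)N[C@@H]1CCC[C@H](C(=O)Nc2cc(-c3cnn(C)c3C)c(Cl)cn2)C1`, read in a physicochemical assay for solubility, in phosphate buffer, at pH 7.4; on this read-out higher numbers stand for higher solubility and lower numbers for lower solubility. In this read-out compound 1 gives 960000 nM, and compound 2 `CC(=O)N[C@@H]1CCC[C@H](C(=O)Nc2cc(-c3cnn4ccccc34)c(Cl)cn2)C1` gives 45000 nM. Compound 3 `CC(=O)N[C@@H]1CCC[C@H](C(=O)Nc2cc(-c3cnc(C)n3C)c(Cl)cn2)C1` gives > 1000000 nM, which is a limit of the assay and not a number.

Compound 4 `CC(=O)N[C@@H]1CCC[C@H](C(=O)Nc2cc(-c3cnn4c3CCC4)c(Cl)cn2)C1` changes the group on an aromatic carbon, ortho to a chloro group and opposite the ring nitrogen: a group of 8 heavy atoms (6 carbon, 2 nitrogen; one five-membered non-aromatic ring with 1 hetero atom, one five-membered aromatic ring with 2 hetero atoms) in place of a group of 7 heavy atoms (5 carbon, 2 nitrogen; one five-membered aromatic ring with 2 hetero atoms), on an aromatic carbon. The 1,2-dimethyl-1H-imidazol-5-yl of compound 3 leaves, and a group with one five-membered aromatic ring and one five-membered non-aromatic ring enters.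

Among the compounds with values here, three measured steps bear on this. The exchange of 1,5-dimethyl-1H-pyrazol-4-yl for 1,2-dimethyl-1H-imidazol-5-yl gives an at least 1.0-fold higher number from compound 1 to compound 3 (0.01 log units; that floor lies within the scatter), whose floor lies within the scatter. The two-ring group of compound 2 marks the large step of a 21-fold lower number from compound 1 to compound 2 (1.33 log units; beyond the scatter), and its mirror is the large step of an at least 22-fold higher number from compound 2 to compound 3 (1.34 log units; beyond the scatter). That group has two aromatic rings, whereas the group in compound 4 has only one, so a fall of that full size is not expected. A lower number of modest size is expected in this assay. The expected step is an at least 2.2-fold lower number from compound 3 to compound 4 (0.34 log units; beyond the scatter). The estimate for compound 4 is 450000 nM, with an expected range from 150000 nM to 1000000 nM.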

Compound 4, solubility: 160000 nM
Compound 4: the middle estimate sits 2.8-fold (0.45 log units) above what was measured; measured number inside the range.
By their numbers in this assay, from the lowest: compound 2; then compound 4; then compound 1. At a limit, above all of these: compound 3.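

In this assay, compound 4 shows that a second ring at this position lowers the number even when that ring is non-aromatic, a 6.0-fold lower number from compound 1 to compound 4 (0.78 log units; beyond the scatter); until now, only the group of compound 2, with its two aromatic rings, had given a fall from compound 1. Within the data shown here, the fall is not the full one, as a 3.6-fold higher number from compound 2 to compound 4 (0.55 log units; beyond the scatter) separates the two two-ring groups, so the three numbers now run in graded order from compound 2 through compound 4 to compound 1, with no measured compound here against the order of two-ring groups below single-ring groups. Compound 3 is a limit of the assay and not a number, which makes an at least 6.2-fold lower number from compound 3 to compound 4 (0.79 log units; beyond the scatter) a floor and not a measured size: the limit of > 1000000 nM in this assay, at which 1 of the 4 values shown sits.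

The compounds shown cannot tell whether the extra ring itself or the added heavy atoms set these steps, nor why the two-ring groups differ from each other. Going by these compounds, it also remains open how the number would respond to an amine or a carboxylic acid carried on the non-aromatic ring of the group in compound 4.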